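The compounds below may be only part of what the source reports. "The series", "measured", "known", "first", "only" and "open" are said of these compounds alone.

Within the data shown here, the two compounds measured so far share a common core and differ in the group carried on an aromatic nitrogen. Compound 1 `CCC(CC)n1c(-c2ccc(OCc3c(-c4c(Cl)cccc4Cl)noc3C(C)C)cc2F)nc2ccc(C(=O)O)cc21` and compound 2 `CC(C)c1onc(-c2c(Cl)cccc2Cl)c1COc1ccc(-c2nc3ccc(C(=O)O)cc3n2CC(C)(C)C)cc1` were both tested in an assay on isolated protein for agonist activity at Bile acid receptor (Homo sapiens), read by TR-FRET; a higher number here means that more compound is needed for the effect, a lower number that less compound is needed. In this assay compound 1 gives 69.3 nM, while compound 2 gives 24.8 nM, the lower of the two numbers, and the gap between them is beyond the usual scatter. The next compound, compound 3 `CCCC(CCC)n1c(-c2ccc(OCc3c(-c4c(Cl)cccc4Cl)noc3C(C)C)cc2)nc2ccc(C(=O)O)cc21`, has not yet been measured. Compared with compound 2, it carries 1-propylbutyl in place of neopentyl on an aromatic nitrogen. Among the measured compounds shown here, no single-change step between measured compounds is available to calibrate this change, so the expectation rests only on the two numbers given. The step from compound 2 to compound 3 is expected to be modest, likely toward a somewhat higher number, as a 2.0-fold higher number from compound 2 to compound 3 (0.30 log units; within the scatter). For compound 3 the estimated value is 50 nM, within a range from 15 nM to 160 nM.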

Compound 3, half-maximal effective concentration: 30.3 nM
Compound 3: the middle estimate sits 1.7-fold (0.22 log units) above what was measured, within the range that was stated.
By their numbers in this assay, from the lowest: compounds 2 and 3 (each within the scatter of the next); then compound 1.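

In this assay, putting 1-propylbutyl in place of neopentyl on the aromatic nitrogen gives a 1.2-fold higher number from compound 2 to compound 3 (0.09 log units; within the scatter). Among these compounds, this is the only single-change step at this position so far, and it shows that going from a group of 5 heavy atoms to one of 7, both all-carbon and without a ring, makes no difference that can be told apart from the scatter. No measurement at hand accounts for why these two groups read alike.

The compounds shown carry only branched carbon chains at this position, so it remains open how a straight chain, a cyclohexyl ring or a chain bearing an amine would read. Going by these compounds, it also remains open how far the chain can grow before the number moves beyond the scatter.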